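This account rests on a few compounds, and the source may have more. Where it says the series, first, only, none or still open, it means among the compounds named here.

In a functional assay on PC-3 cells (Homo sapiens) for inhibition, read by MTT assay, with a stated time of 48 h, tested at 10 uM (on this read-out higher numbers stand for more inhibition of growth at the one concentration tested and lower numbers for less inhibition of growth), compound 1 `Cc1cc(=O)c2c(O)c(CN3CCC(N4CCCCC4)CC3)c(O)c([C@H]3CCN(C)C[C@H]3O)c2o1` gives 17% and compound 2 `Cc1cc(=O)c2c(O)c(CN3CCCCC3)c(O)c([C@H]3CCN(C)C[C@H]3O)c2o1` gives 14%. Compound 3 `Cc1oc2c([C@H]3CCN(C)C[C@H]3O)c(O)cc(O)c2c(=O)c1C(O)c1ccc(F)c(Br)c1` reaches 72%, the highest of the three numbers and beyond the scatter from both of the others. Compound 4 `Cc1oc2c([C@H]3CCN(C)C[C@H]3O)c(O)cc(O)c2c(=O)c1C(O)c1cccc(Cl)c1Cl` departs from compound 3 in one place: 2,3-dichlorophenyl in place of 3-bromo-4-fluorophenyl on a saturated chain carbon bound to an aromatic carbon and an oxygen on a saturated carbon.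

Among the measured compounds shown here, the only measured step between close relatives is a number 3 percentage points lower from compound 1 to compound 2 (within the scatter). That change concerns a saturated ring carbon rather than the phenyl group, so it gives no direct measure of the exchange at hand. For the measured compounds named here, no measured pair swaps one halogen-bearing phenyl group for another, and the size of this step remains open.

What the data do offer is a comparison of values. Going by the values given here, compound 3, at 72%, is the only measured compound with a halogen-bearing phenyl group, and compound 4 keeps such a group with the same count of heavy atoms. Compound 4 is therefore expected to stay much closer to compound 3 than to compound 1 or compound 2, though with wide uncertainty. The expected change in this assay is a modest fall, a number 10 percentage points lower from compound 3 to compound 4 (within the scatter), which may not exceed the scatter. For compound 4 the estimate is 62%, with an expected range from 38% to 82%.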

Compound 4, percent growth inhibition at one concentration: 20%
Compound 4: the middle estimate sits 42 percentage points above what was measured; measured number outside the range, below it.
By their numbers in this assay, from the lowest: compounds 2, 1 and 4 (each within the scatter of the next); then compound 3.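

In this assay, among the compounds shown here, the exchange of 3-bromo-4-fluorophenyl for 2,3-dichlorophenyl, on a saturated chain carbon bound to an aromatic carbon and an oxygen on a saturated carbon, gives a number 52 percentage points lower from compound 3 to compound 4 (beyond the scatter) and is the first step between close relatives to pass the usual scatter. It shows that this place responds strongly to the halogen pattern of its phenyl group: carrying a halogen-bearing phenyl group is not enough to keep the number high, even though both groups have the same count of heavy atoms, the same aromatic ring and no hydrogen-bond donors or acceptors. No measurement in hand accounts for why these two groups part so widely.

Both halogens and their places on the ring change in this one step, so the compounds shown leave open which of these differences carries the fall. On these data alone, how a plain phenyl, 3-bromophenyl, 4-fluorophenyl or 3,4-dichlorophenyl group would stand at this place remains unknown, and with it whether the number of compound 3 depends on the bromine, the fluorine or the two together.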